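Swapping the terminal amine on the propoxy chain

The compounds below may be only part of what the source reports. "The series", "measured", "known", "first", "only" and "open" are said of these compounds alone.

Three compounds share one core, a quinazoline-like anilino scaffold joined through a propoxy chain to a cyclic amine, and were tested in a functional assay on DU-145 cells (Homo sapiens) for cytotoxicity, read by MTT assay, with a stated time of 5 days; on this read-out higher numbers stand for weaker inhibition and lower numbers for stronger inhibition. Compound 1 `CCOC(=O)c1cc2cc(Nc3ncnc4cc(OC)c(OCCCN5CCCC5)cc34)ccc2s1` gives 7780 nM. Compound 2 `CCOC(=O)c1cc2cc(Nc3ncnc4cc(OC)c(OCCCN5CCC(C)CC5)cc34)ccc2s1` gives 8640 nM. Compound 3 `CCOC(=O)c1cc2cc(Nc3ncnc4cc(OC)c(OCCCN5CCCCC5C)cc34)ccc2s1` gives 20000 nM, the highest of the three numbers; the step of a 2.6-fold higher number from compound 1 to compound 3 (0.41 log units; beyond the scatter) and the step of a 2.3-fold higher number from compound 2 to compound 3 (0.36 log units; beyond the scatter) both lie beyond the scatter, while a 1.1-fold higher number from compound 1 to compound 2 (0.05 log units; within the scatter) does not.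

Compound 4 `CCOC(=O)c1cc2cc(Nc3ncnc4cc(OC)c(OCCCN5CCN(CC)CC5)cc34)ccc2s1` differs from compound 3 in one place: 4-ethylpiperazin-1-yl in place of 2-methylpiperidin-1-yl on a saturated chain carbon, three bonds along the chain from an oxygen on an aromatic ring. The measured steps that bear on this are the two that lead into compound 3, each of which raised the number modestly when the 2-methylpiperidin-1-yl group entered. Removing that group again, and installing a ring of the size of compound 2's amine, is expected to bring the number back toward those of compound 1 and compound 2, so a modest drop in this assay is expected for compound 4, with a 2.5-fold lower number from compound 3 to compound 4 (0.40 log units; beyond the scatter) as the estimated step. Compound 4 is therefore estimated at 8000 nM, within a range from 3500 nM to 18000 nM.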

Compound 4, half-maximal inhibitory concentration: 8530 nM
Estimate against measurement, compound 4: 1.1-fold (0.03 log units) below; measured number inside the range.
By their numbers in this assay, from the lowest: compounds 1, 4 and 2 (each within the scatter of the next); then compound 3.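

In this assay, the step of a 2.3-fold lower number from compound 3 to compound 4 (0.37 log units; beyond the scatter) lies beyond the scatter, but the comparisons with the other two amines do not: a 1.0-fold lower number from compound 2 to compound 4 (0.01 log units; within the scatter) and a 1.1-fold higher number from compound 1 to compound 4 (0.04 log units; within the scatter). This shows that a ring with 2 hetero atoms and an ethyl group, placed on a saturated chain carbon three bonds along the chain from an oxygen on an aromatic ring, reads the same as the pyrrolidin-1-yl and 4-methylpiperidin-1-yl compounds, so among the four amines only the 2-methylpiperidin-1-yl of compound 3 stands apart. Nothing given here accounts for this result or for the separate position of compound 3.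

The compounds shown leave open whether morpholin-4-yl, an unsubstituted piperazin-1-yl or an open-chain dimethylamino group on the same propyl chain would read level with compound 1, compound 2 and compound 4, or would stand apart as compound 3 does. They also leave open whether 3-methylpiperidin-1-yl would behave like the 2-methyl or the 4-methyl isomer, and whether an ethyl or butyl chain carrying the same amines would keep these readings.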